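A few compounds are considered here, and "the series" means these few. Any claim that something is new, unique, unknown or untested is made for them only; others in the source may bear on it.

Among the measured compounds shown here, compound 3 `CC(C(=O)NCc1ccc(C(C)(C)C)nc1SCc1ccccc1Cl)c1ccc(NS(C)(=O)=O)c(F)c1` gives 3.8 nM in an assay on cells for antagonist activity at transient receptor potential cation channel subfamily V member 1 (Homo sapiens), read by FLIPR and calcium flux, with a stated time of 6 min (a lower number here means a stronger inhibitor, a higher number a weaker inhibitor), the highest of the three numbers so far, though its gap to compound 1 lies within the scatter. Compound 1 `CC(C)Oc1nc(C(C)(C)C)ccc1CNC(=O)C(C)c1ccc(NS(C)(=O)=O)c(F)c1` gives 2.3 nM, and compound 2 `CC(C(=O)NCc1ccc(C(C)(C)C)nc1OCc1ccc(F)cc1)c1ccc(NS(C)(=O)=O)c(F)c1` gives 0.8 nM. The steps at this position are a 1.7-fold higher number from compound 1 to compound 3 (0.22 log units; within the scatter), a 2.9-fold lower number from compound 1 to compound 2 (0.46 log units; beyond the scatter) and a 4.8-fold higher number from compound 2 to compound 3 (0.68 log units; beyond the scatter). Compound 4 `CC(C(=O)NCc1ccc(C(C)(C)C)nc1C1CCCCC1)c1ccc(NS(C)(=O)=O)c(F)c1` carries cyclohexyl in place of (2-chlorobenzyl)sulfanyl on an aromatic carbon. For the measured compounds named here, no measured step brings in a non-aromatic ring here, so the bearing of the three steps is indirect; they show that changing the group at this position moves the number only modestly in either direction. The expected step is a 1.6-fold higher number from compound 3 to compound 4 (0.20 log units; within the scatter), a small shift upward in this assay. Compound 4 is estimated at 6 nM, with a range of 1.5 nM to 25 nM.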

Compound 4, inhibition constant: 3.1 nM
The estimate for compound 4 lay 1.9-fold (0.29 log units) above the measured number; the measured number falls inside the stated range.
By their numbers in this assay, from the lowest: compound 2; then compounds 1, 4 and 3 (each within the scatter of the next).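

Cyclohexyl, a non-aromatic ring of carbon only, stands on the aromatic carbon with no linking oxygen or sulfur and still falls level with two of the earlier groups, with a 1.2-fold lower number from compound 3 to compound 4 (0.09 log units; within the scatter) and a 1.3-fold higher number from compound 1 to compound 4 (0.13 log units; within the scatter) both within the scatter. Among the compounds shown here, the (4-fluorobenzyl)oxy group alone stays apart, with a 3.9-fold higher number from compound 2 to compound 4 (0.59 log units; beyond the scatter) as the one new step beyond the scatter. No measured evidence accounts for these steps.

Still open, on these data alone, is how a ring amine such as piperidine or morpholine would read at this position. As far as these compounds go, a smaller carbon ring such as cyclopentyl, or a phenyl ring joined directly, also remains open.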